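Removing the acetamidomethyl chain from compound 2

This account rests on a few compounds, and the source may have more. Where it says the series, first, only, none or still open, it means among the compounds named here.

Compound 1 `CC(=O)N1CCc2c(C)c3c(n2-c2ccc(C(N)=O)c(c2)N[C@@H](C)CC1)CC(C)(C)CC3=O`: 0.15 h
Compound 2 `CC(=O)NCCN1CC[C@H](C)Nc2cc(ccc2C(N)=O)-n2c(c(C)c3c2CC(C)(C)CC3=O)CC1=O`: a limit, > 0.5 h
Compound 3 `CC(=O)NCC(=O)N1CCc2c(C)c3c(n2-c2ccc(C(N)=O)c(c2)N[C@@H](C)CC1)CC(C)(C)CC3=O`: a limit, > 0.5 h

In an in vitro ADME assay on microsomes from liver (Rattus norvegicus) for metabolic stability (on this read-out higher numbers stand for a longer-lived compound and lower numbers for a shorter-lived compound), compound 1 gives 0.15 h. For compound 2 this assay reports only a limit, > 0.5 h. For compound 3 this assay likewise reports a limit, > 0.5 h. Compound 2 therefore stands at the limit of > 0.5 h in this assay, at which 2 of the 3 values shown sit, and no number is known for it. Compound 4 `Cc1c2c(n3c1CC(=O)N(C)CC[C@H](C)Nc1cc-3ccc1C(N)=O)CC(C)(C)CC2=O` is not yet measured; it differs from compound 2 by hydrogen in place of acetamidomethyl on a saturated chain carbon bound to an amide-type nitrogen in a ring. Going by the values given here, the only measured step bears on this change in the opposite direction: an at least 3.3-fold higher number from compound 1 to compound 3 (0.52 log units; beyond the scatter). Taking the acetamido-bearing chain away is therefore expected to shorten the half-life, and compound 4 is expected to give 0.2 h (range 0.08 h to 0.5 h), which would mean an at least 2.5-fold lower number from compound 2 to compound 4 (0.39 log units; beyond the scatter).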

Compound 4, half-life: > 0.5 h
Compound 4 ended at the assay's limit; the forecaster's own chance of this, stated with the estimate: 20%; middle value at least 2.5-fold (0.39 log units) from the limit.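

Compound 2 and compound 4 both stand only as limits, so no step between them can be read: the limit of > 0.5 h in this assay, at which 3 of the 4 values shown sit.

Going by these compounds, how far either half-life lies past that limit, and whether hydrogen in place of acetamidomethyl changes it at all, stays open.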